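The step from compound 1 to compound 4

This account rests on a few compounds, and the source may have more. Where it says the series, first, only, none or still open, it means among the compounds named here.

The series is followed in an ADME assay on liver for metabolic stability, with Liver microsome (Homo sapiens) as the target, read by LC-MS, using microsomes; a higher number here means faster removal of the compound, a lower number slower removal. Compound 1 `O=C(NCc1cc(Cl)ccc1-n1cnnn1)[C@@H]1C[C@@H]2C[C@@H]2N1C(=O)[C@H](O)Cn1cccn1` gives < 12 mL.min-1.g-1 as a limit of the assay and not a number. For the measured compounds named here, compound 2 `O=C(NCc1cc(Cl)ccc1-n1cnnn1)[C@@H]1CC=NN1C(=O)[C@H](O)c1ccccc1F` gives 16 mL.min-1.g-1 and is the only compound here with a measured number. On these data alone, compound 1 therefore stands at a limit, and its true place on the scale remains open.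

Compound 4 `COC(C)(C)[C@@H](O)C(=O)N1[C@H](C(=O)NCc2cc(Cl)ccc2-n2cnnn2)C[C@@H]2C[C@@H]21` keeps the core of compound 1 and differs at one place 1-methoxy-1-methylethyl in place of (1H-pyrazol-1-yl)methyl on a saturated chain carbon bound to a carbonyl carbon and an oxygen on a saturated carbon with 1-methoxy-1-methylethyl in place of (1H-pyrazol-1-yl)methyl on a saturated chain carbon bound to a carbonyl carbon and an oxygen on a saturated carbon. Going by the values given here, no measured pair isolates this exchange, so any expectation is indirect. Compound 4 looks closest in this group to compound 3 `CC(C)(C)[C@@H](O)C(=O)N1C[C@@H]2C[C@@H]2[C@H]1C(=O)NCc1cc(Cl)ccc1-n1cnnn1` which stands at the limit of < 15 mL.min-1.g-1 in this assay. A small upward step, not clearly beyond the scatter, is expected. The estimated step is an at least 1.1-fold higher number from compound 1 to compound 4 (0.06 log units; that floor lies within the scatter) in size. For compound 4 the estimate is 14 mL.min-1.g-1 with an expected range from 8 mL.min-1.g-1 to 28 mL.min-1.g-1.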

Compound 4, intrinsic clearance in microsomes: 40 mL.min-1.g-1
Compound 4: the middle estimate sits 2.9-fold (0.46 log units) below what was measured, and the stated range ends below it.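

For the compounds shown here, this is the first single exchange read at this place, on a saturated chain carbon bound to a carbonyl carbon and an oxygen on a saturated carbon. In this assay, going by these compounds alone, 1-methoxy-1-methylethyl in place of (1H-pyrazol-1-yl)methyl gives an at least 3.3-fold higher number from compound 1 to compound 4 (0.52 log units; beyond the scatter), so the read-out responds to this group with the core of compound 1 held fixed, which no earlier pair could show. The step is a floor and not a full size, because compound 1 stands at a limit of the assay: the limit of < 12 mL.min-1.g-1 in this assay, at which 1 of the 4 values shown sits.

Within the data shown here, the single exchange does not separate the loss of the aromatic ring from the entry of the methoxy oxygen. On these data alone, how an amine, a carboxylic acid or a longer alkyl chain at this place would read in this assay also remains open.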